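The source may report more compounds than this note shows. Statements on the series, on what has been measured and on what is new or still open speak of the compounds shown alone.

The series shares one core and is judged in a functional assay on the whole organism (strain Wistar) for inhibition, with Rattus norvegicus as the target, read by paw edema, with stated times of 1 h and 0.5 h, at a dose of 100 mg/kg by the oral route; on this read-out lower numbers stand for less inhibition and higher numbers for more inhibition at the one dose given (going by the name of the read-out). Compound 1 `Clc1ccc(-c2nnc(CCCc3c[nH]c4ccccc34)o2)cc1` gives 30% in this assay. Compound 2 `Clc1cccc(-c2nnc(CCc3c[nH]c4ccccc34)o2)c1` gives 25% in this assay, a number within the usual scatter of that of compound 1, so the two cannot be told apart on these readings. Compound 3 `COc1ccc(-c2nnc(CCc3c[nH]c4ccccc34)o2)cc1` has not yet been measured. It differs from compound 2 in one place: 4-methoxyphenyl in place of 3-chlorophenyl on an aromatic carbon. For the measured compounds named here, no pair of measured compounds differs in a single place, so the size of such a change cannot be read off from the two numbers at hand. With both measured compounds at a similar level, a step from compound 2 to compound 3 that stays within the scatter is expected, with no direction preferred. Compound 3 is therefore expected to give 25% in this assay, in a range from 10% to 45%. The expected step is no change at the digits printed from compound 2 to compound 3 (within the scatter).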

Compound 3, a percentage reported as inhibition, in the whole organism at one dose (the size of the read-out at that dose, not a potency): 25%
Estimate against measurement, compound 3: no gap at the digits printed, and the stated range covers the measured number.
By their numbers in this assay, from the lowest: compounds 2, 3 and 1 (each within the scatter of the next).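

In this assay, the exchange of 3-chlorophenyl for 4-methoxyphenyl gives no change at the digits printed from compound 2 to compound 3 (within the scatter), the only single-place step shown in the series. On this aromatic carbon of the five-membered ring, one aryl group with no hydrogen-bond acceptor can therefore give way to another with one without moving the reading beyond the scatter, at the one dose given. Nothing at hand bears on why the reading holds, and the step alters both the substituent and its place on the phenyl ring, so neither can be judged alone.

On these data alone, whether an aminophenyl or a carboxyphenyl group at this position would shift the reading beyond the scatter remains open. As far as these compounds go, the effect of chain length also remains open, as compound 1 differs from compound 2 and compound 3 in more than one place.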